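This account rests on a few compounds, and the source may have more. Where it says the series, first, only, none or still open, it means among the compounds named here.

Compound 1 `ClCc1ccc(Cn2cnc3c(Cl)ncnc32)cc1` and compound 2 `Nc1nc(Cl)c2ncn(Cc3ccc(CCl)cc3)c2n1` are built on one shared core, and compound 2 differs from compound 1 only by amino in place of hydrogen on an aromatic carbon. In a functional assay on EKVX cells (Homo sapiens) for cytotoxicity, read by sulforhodamine B assay, with a stated time of 48 h (on this read-out lower numbers stand for stronger inhibition of growth and higher numbers for weaker inhibition of growth), compound 1 gives 2450 nM, while compound 2 gives 2570 nM, so that a 1.0-fold higher number from compound 1 to compound 2 (0.02 log units; within the scatter). Compound 3 `ClCc1ccccc1Cn1cnc2c(Cl)ncnc21` contains the same atoms as compound 1 joined differently; the difference between the two cores is not broken down here. In this assay compound 3 gives 3090 nM. Compound 4 `Nc1nc(Cl)c2ncn(Cc3ccccc3CCl)c2n1` stands to compound 3 as compound 2 stands to compound 1, namely by amino in place of hydrogen on an aromatic carbon, the same change at the same place. Compound 4 is therefore expected to sit close to compound 3, with an estimated step of a 1.0-fold higher number from compound 3 to compound 4 (0.00 log units; within the scatter), resting on the step from compound 1 to compound 2 of a 1.0-fold higher number from compound 1 to compound 2 (0.02 log units; within the scatter). The estimate for compound 4 in this assay is 3100 nM, within 1500 nM to 6500 nM.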

Compound 4, concentration for 50% growth inhibition: 15900 nM
Beside the measured number, compound 4's estimate is 5.1-fold (0.71 log units) below it; the whole stated range lies below it.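

In this assay, amino in place of hydrogen on an aromatic carbon gives a 5.1-fold higher number from compound 3 to compound 4 (0.71 log units; beyond the scatter), so on this core the change goes with weaker inhibition of growth. The change therefore does not carry over unchanged between the two cores: the same change on two cores in this assay, a 1.0-fold higher number (0.02 log units; within the scatter) from compound 1 to compound 2 and a 5.1-fold higher number (0.71 log units; beyond the scatter) from compound 3 to compound 4, 4.9-fold (0.69 log units) apart, beyond the scatter of two such steps. This shows that the size of the step differs between these two pairs, but two pairs give no general rule for other cores and do not show which difference between the cores matters.

The compounds shown leave open whether a methylamino group or a hydroxyl group at the same place would behave like amino on either core. They also leave open how either step would look if the chloro group were exchanged for a methoxy group.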